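Aryl swap to 4-iodophenyl on the cinnamamide series

The compounds below may be only part of what the source reports. "The series", "measured", "known", "first", "only" and "open" are said of these compounds alone.

Compound 1 `CCCc1cc(N)c2cc(NC(=O)/C=C/c3ccc(O)cc3)ccc2n1` gives 1100 nM in an assay on isolated protein for displacement of a labelled ligand from melanin-concentrating hormone receptor 1 (Homo sapiens); a higher number here means a weaker inhibitor, a lower number a stronger inhibitor. Compound 2 `CCCc1cc(N)c2cc(NC(=O)/C=C/c3cccc(Cl)c3)ccc2n1` gives 1100 nM in this assay, and the step of no change at the digits printed from compound 1 to compound 2 (within the scatter) shows the aryl swap left the value level. Compound 3 `CCCc1cc(N)c2cc(NC(=O)/C=C/c3ccc(I)cc3)ccc2n1` carries 4-iodophenyl in place of 3-chlorophenyl on a double-bonded chain carbon bound to a double-bonded chain carbon. Going by the values given here, only the step from compound 1 to compound 2 bears on this change, and it was flat, so no step beyond the scatter is expected in this assay in either direction. Compound 3 is therefore expected to give about 1100 nM, with a range from 400 nM to 3000 nM. The expected step is no change at the digits printed from compound 2 to compound 3 (within the scatter).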

Compound 3, half-maximal inhibitory concentration: 2.3 nM
Compound 3: the middle estimate sits 480-fold (2.68 log units) above what was measured, and the stated range ends above it.
By their numbers in this assay, from the lowest: compound 3; then compounds 1 and 2 (each within the scatter of the next).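

In this assay, the aryl group on this double-bonded chain carbon can move the number sharply, with a 480-fold lower number from compound 2 to compound 3 (2.68 log units; beyond the scatter) and a 480-fold lower number from compound 1 to compound 3 (2.68 log units; beyond the scatter), which the flat earlier step gave no sign of. The second of these is a single swap, iodo in place of hydroxy on an aromatic carbon, so the large drop goes with that exchange on the ring. Nothing available here accounts for the size of the drop.

The swap from 3-chlorophenyl to 4-iodophenyl alters both the halogen and its ring location, and the compounds shown cannot separate the two. On these data alone, whether 4-chlorophenyl, 4-bromophenyl or 3-iodophenyl would share the low number remains open.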